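This account rests on a few compounds, and the source may have more. Where it says the series, first, only, none or still open, it means among the compounds named here.

Compounds measured so far:
compound 1 `Nc1cnc2c(OCc3ccccc3)cccn12` — 32%
compound 2 `Cc1nc2c(OCc3ccccc3)cccn2c1NC(=O)OCc1ccccc1` — 8%
compound 3 `CNC(=O)Nc1c(C)nc2c(OCc3ccccc3)cccn12` — 22%

All three share one core and were tested in a functional assay on the whole organism with Rattus norvegicus as the target, at a dose of 40 mg/kg by the intraperitoneal route; a lower number here means less inhibition, a higher number more inhibition at the dose given (going by the name of the read-out). Compound 3 gives 22%, the second highest of the three numbers; compound 1 gives 32%, which lies within the scatter of compound 3, while compound 2 gives 8%, which lies beyond it. Going by the values given here, the one single-point step measured so far, a number 14 percentage points higher from compound 2 to compound 3 (beyond the scatter), came from swapping methylamino for benzyloxy on a carbonyl carbon.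

Compound 4 `CCCN(CCC)c1c(C)nc2c(OCc3ccccc3)cccn12` has not been measured. It differs from compound 3 as follows: dipropylamino in place of (methylcarbamoyl)amino on an aromatic carbon. Among the compounds with values here, no measured step involves a dipropylamino group, so the change is of a new kind; the only step that bears on it at all is the modest a number 14 percentage points higher from compound 2 to compound 3 (beyond the scatter), which touched the same attachment point. A change of similar size in either direction, or none beyond the scatter, is therefore expected. Compound 4 is estimated at 20%, with a range of 0% to 45%, meaning an expected step of a number 2 percentage points lower from compound 3 to compound 4 (within the scatter).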

Compound 4, a percentage reported as inhibition, in the whole organism at one dose (the size of the read-out at that dose, not a potency): 60%
Beside the measured number, compound 4's estimate is 40 percentage points below it; measured number above the stated range.
By their numbers in this assay, from the lowest: compound 2; then compounds 3 and 1 (each within the scatter of the next); then compound 4.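

In this assay putting dipropylamino in place of (methylcarbamoyl)amino on this aromatic carbon gives a number 38 percentage points higher from compound 3 to compound 4 (beyond the scatter) and so shows that this position can shift the read-out far more than the earlier step suggested. That earlier step kept the carbonyl attached to the nitrogen at this position, whereas this change removes the carbonyl and all hydrogen-bond donors from the group and adds heavy atoms, all in a single swap, so the compounds cannot separate these features. Nothing measured here accounts for the size of the step.

On these data alone, whether a smaller dimethylamino group, a longer dibutylamino group or a single propylamino chain would give a similar read-out stays open. So does whether a ring amine such as piperidine would serve in the same place.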